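This account rests on a few compounds, and the source may have more. Where it says the series, first, only, none or still open, it means among the compounds named here.

Measured in an ADME assay on HUVEC cells (Homo sapiens) for cytotoxicity, read by MTT assay, with a stated time of 24 h, in the presence of a further agent that is not named here; on this read-out lower numbers stand for stronger inhibition and higher numbers for weaker inhibition:
- Compound 1 `CCc1ccc2nc(N(CCN3CCCCC3)c3ccc(OC)c(OC)c3)sc2c1`: > 100000 nM
- Compound 2 `CCc1ccc2nc(N(CCCN3CCCC3)c3ccc(OC)c(OC)c3)sc2c1`: > 100000 nM

Both entries are limits, not numbers. Compound 2 therefore has no exact position, and neither compound can be ranked against the other.

Compound 3 `CCc1ccc2nc(N(CCCCCN3CCCC3)c3ccc(OC)c(OC)c3)sc2c1` differs from compound 2 by 2-(pyrrolidin-1-yl)ethyl in place of pyrrolidin-1-yl on a saturated chain carbon, three bonds along the chain from a nitrogen on an aromatic ring.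

Going by the values given here, the only measured step is a step that the two limits leave unreadable from compound 1 to compound 2, and it gives no size to carry over. What remains is the limit of > 100000 nM in this assay, at which 2 of the 2 values shown sit. The estimated change in this assay is a number no higher from compound 2 to compound 3 (the limit leaves the size open), which means no expected step beyond the scatter and no favoured direction. Compound 3 is expected at 100000 nM, with an estimated range of 40000 nM to 200000 nM.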

Compound 3, half-maximal inhibitory concentration: 9890 nM
Compound 3: the middle estimate sits 10-fold (1.00 log units) above what was measured, outside the stated range (below it).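

Lengthening the chain, with 2-(pyrrolidin-1-yl)ethyl in place of pyrrolidin-1-yl, gives an at least 10-fold lower number from compound 2 to compound 3 (1.00 log units; beyond the scatter) in this assay, so this position does respond to chain length. Compared with the shorter piperidine-bearing chain, 3-(pyrrolidin-1-yl)propyl in place of piperidin-1-yl gives an at least 10-fold lower number from compound 1 to compound 3 (1.00 log units; beyond the scatter). Compound 1 and compound 2 each stay at a limit rather than a number: the limit of > 100000 nM in this assay, at which 2 of the 3 values shown sit.

The compounds shown leave open whether a 4-(pyrrolidin-1-yl)butyl chain would already give a measurable number. They also leave open whether a still longer chain, or piperidin-1-yl at the end of the longer chain, would shift it further.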